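The source may hold more compounds than are shown below. What is called first, only, known or untested is meant among the compounds shown, and "the series" means these compounds.

Of the compounds shown here, three sharing one core have been measured in a functional assay on HL-60 cells (Homo sapiens), with a stated time of 2 days; a higher number here means a weaker inhibitor, a lower number a stronger inhibitor. Compound 1 (`O=C(NCc1ccccc1)c1nc[nH]c1C(=O)Nc1ccc(Cl)c(Cl)c1`) gives 11500 nM, compound 2 (`Cc1ccc(CNC(=O)c2[nH]cnc2C(=O)Nc2ccc(Cl)c(Cl)c2)cc1`) gives 21400 nM, and compound 3 (`COc1ccc(CNC(=O)c2[nH]cnc2C(=O)Nc2ccc(Cl)c(Cl)c2)cc1`) gives 24300 nM. Compound 3 cannot be told apart from compound 2, while its number is clearly higher than that of compound 1.

The next compound, compound 4 (`COC(=O)[C@H](NC(=O)c1[nH]cnc1C(=O)Nc1ccc(Cl)c(Cl)c1)C(C)C`), has not yet been measured. It carries 1-(methoxycarbonyl)-2-methylpropyl in place of the 4-methoxybenzyl of compound 3 on an amide-type nitrogen: 1-(methoxycarbonyl)-2-methylpropyl in place of 4-methoxybenzyl on an amide-type nitrogen. The aromatic ring of that group leaves, and the group that enters has no ring.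

Among the compounds with values here, only one measured step offers any guide. That step, a 1.1-fold higher number from compound 2 to compound 3 (0.06 log units; within the scatter), lay within the scatter, but it exchanged methoxy for methyl on an aromatic carbon and kept the ring, so it bears only weakly on a change this large. Within the data shown here, no measured compound lacks that ring, so the data point in neither direction. No shift beyond the scatter is therefore expected in this assay, although the uncertainty is wide. The expected change is a 1.0-fold lower number from compound 3 to compound 4 (0.01 log units; within the scatter). Compound 4 is estimated at 24000 nM, with an expected range from 8000 nM to 70000 nM.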

Compound 4, half-maximal inhibitory concentration: 8500 nM
The estimate for compound 4 lay 2.8-fold (0.45 log units) above the measured number, and the stated range covers the measured number.
By their numbers in this assay, from the lowest: compounds 4, 1, 2 and 3 (each within the scatter of the next, the first and the last beyond it).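

In this assay this amide-type nitrogen tolerates a group with no ring: putting 1-(methoxycarbonyl)-2-methylpropyl in place of 4-methoxybenzyl gives a 2.9-fold lower number from compound 3 to compound 4 (0.46 log units; beyond the scatter) and putting it in place of 4-methylbenzyl gives a 2.5-fold lower number from compound 2 to compound 4 (0.40 log units; beyond the scatter), so the aromatic ring of these benzyl groups is not needed to reach this level of activity. The advantage does not extend to the unsubstituted benzyl group, however: compound 1 gives 11500 nM and compound 4 gives 8500 nM, and these two numbers lie within the scatter of each other. No available evidence accounts for the difference between compound 4 and compounds 2 and 3.

Within the data shown here, the single ringless example does not separate the contributions of its methyl ester, its branched isopropyl-type chain and its defined stereocentre, so the change could rest on any of these parts or on their combination. A carboxylic acid or a primary amide in place of the methyl ester, a straight butyl chain, and the opposite stereocentre would each test one of those parts on its own.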